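Adding a basic side chain to a piperidine amine

The source may report more compounds than this note shows. Statements on the series, on what has been measured and on what is new or still open speak of the compounds shown alone.

Measured compounds and their values:
- compound 1, `COc1cc(N)c(Cl)cc1C(=O)NC1CCNCC1`: 1580 nM
- compound 2, `CC(C)n1c(=O)n(C(=O)NC2CCNCC2)c2ccccc21`: 1580 nM
- compound 3, `COc1cc(N)c(Cl)cc1C(=O)NC1CCN(CCCCCCCCN2C(=O)c3ccccc3C2=O)CC1`: 39.8 nM

All three numbers come from an assay on HEK293 cells for displacement of a labelled ligand from 5-hydroxytryptamine receptor 4 (Homo sapiens), read by scintillation counting; a higher number here means a weaker inhibitor, a lower number a stronger inhibitor. Compound 1 and compound 2 stand level at the digits shown, and together they give the highest numbers of the three. Within the data shown here, compound 3 sits far below them: its number is lower than that of compound 1 by a margin well beyond the scatter, and it is the only compound here with a substituent on the ring amine nitrogen.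

Compound 4, `COc1cc(N)c(Cl)cc1C(=O)NC1CCN(CCN2CCCCC2)CC1`, is not yet measured. It differs from compound 1 in one place: 2-(piperidin-1-yl)ethyl in place of hydrogen on an amine nitrogen in a ring. The core of compound 1 is otherwise kept.

Among the measured compounds shown here, no step between measured compounds matches this exact change, so the expectation rests on what the two values show. Compound 1, unsubstituted on that nitrogen, gives 1580 nM, while compound 3, carrying a long chain there, gives 39.8 nM. A shorter chain ending in a ring is expected to move the number in the same direction, though by less than the full gap to compound 3. The step from compound 1 to compound 4 in this assay is therefore expected to be a 13-fold lower number from compound 1 to compound 4 (1.10 log units; beyond the scatter). Compound 4 is estimated at 126 nM, within a range from 32 nM to 500 nM.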

Compound 4, inhibition constant: 251 nM
The estimate for compound 4 lay 2.0-fold (0.30 log units) below the measured number; the range from low to high includes it.
By their numbers in this assay, from the lowest: compound 3; then compound 4; then compounds 1 and 2 (each within the scatter of the next).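

In this assay, placing 2-(piperidin-1-yl)ethyl instead of hydrogen on the amine nitrogen in the ring gives a 6.3-fold lower number from compound 1 to compound 4 (0.80 log units; beyond the scatter). Among these compounds, this is the first pair of compounds that differ only at this position, so the drop can be tied to this one change with the rest of compound 1 kept, a link that the earlier compounds could not provide. The group on this nitrogen also sets how far the number falls, since compound 4 at 251 nM stands above compound 3 at 39.8 nM, and nothing shown explains the size of the step.

The compounds shown leave open whether the piperidine ring at the end of the new group matters or the chain alone is enough, a question that a plain ethyl group or a morpholine ring in place of the piperidine on the same two-carbon chain could help to settle. They also leave open how a butyl or hexyl chain ending in piperidine would compare, and whether the core of compound 2 would respond in the same way to 2-(piperidin-1-yl)ethyl.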